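A Chlorine Group Replaces Methyl in a Weak Series

The source may report more compounds than this note shows. Statements on the series, on what has been measured and on what is new or still open speak of the compounds shown alone.

Within the data shown here, in a functional assay on SGC-7901 cells (Homo sapiens) for antiproliferative activity, read by MTT assay, with a stated time of 24 h (a higher number here means a weaker inhibitor, a lower number a stronger inhibitor), compound 3 `Cc1ccc(C(=O)NNC(=O)c2cccc(NS(=O)(=O)c3cnc(O)nc3O)c2)cc1` gives 10100 nM, the only true number so far. Compound 1 `Cc1ccccc1NNC(=O)c1cccc(NS(=O)(=O)c2cnc(O)nc2O)c1` reads > 20000 nM, which is a limit of the assay. Compound 2 `Cc1ccccc1C(=O)NNC(=O)c1cccc(NS(=O)(=O)c2cnc(O)nc2O)c1` reads > 20000 nM, also a limit. Compound 4 `O=C(NNC(=O)c1cccc(NS(=O)(=O)c2cnc(O)nc2O)c1)c1cccc(Cl)c1` carries one change from compound 3: 3-chlorophenyl in place of 4-methylphenyl on a carbonyl carbon. Among the measured compounds shown here, only one measured step touches that place: 4-methylphenyl in place of 2-methylphenyl on a carbonyl carbon gave an at least 1.9-fold lower number from compound 2 to compound 3 (0.29 log units; that floor lies within the scatter). That size is only a floor, and it stays within the scatter, so no step beyond the scatter is expected in this assay. The estimated step is a 1.2-fold higher number from compound 3 to compound 4 (0.07 log units; within the scatter). For compound 4 the expected value is 12000 nM, with an estimated range of 6000 nM to 24000 nM.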

Compound 4, half-maximal inhibitory concentration: 7310 nM
The estimate for compound 4 lay 1.6-fold (0.22 log units) above the measured number; low and high end bracket the measured number.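

In this assay, 3-chlorophenyl in place of 4-methylphenyl on a carbonyl carbon gives a 1.4-fold lower number from compound 3 to compound 4 (0.14 log units; within the scatter), so these two groups cannot be told apart here. Two steps now clear the scatter, the first in this series: an at least 2.7-fold lower number from compound 2 to compound 4 (0.43 log units; beyond the scatter), and an at least 2.7-fold lower number from compound 1 to compound 4 (0.43 log units; beyond the scatter). Both are only floors, set by a limit of the assay: the limit of > 20000 nM in this assay, at which 2 of the 4 values shown sit.

Chlorine for methyl and the new place on the ring arrive together in compound 4, so their shares cannot be separated. As far as these compounds go, whether an amine or a carboxylic acid on this phenyl ring would shift the number stays open.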